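Aryl replacement on the pyrimidine core and NF-kappa-B inhibition

The compounds below may be only part of what the source reports. "The series", "measured", "known", "first", "only" and "open" are said of these compounds alone.

The series shares one core carrying an ethoxycarbonyl group and a hydrazinyl-linked imide, and differs only in the group on the aromatic carbon between the two ring nitrogen atoms. Compound 1 `CCOC(=O)c1cnc(C)nc1NN1C(=O)C=C(C)C1=O` gives 16000 nM in a functional assay on Jurkat cells for inhibition of nuclear factor NF-kappa-B complex (Homo sapiens); on this read-out lower numbers stand for stronger inhibition and higher numbers for weaker inhibition. Compound 2 `CCOC(=O)c1cnc(-c2ccc(Cl)cc2)nc1NN1C(=O)C=C(C)C1=O` gives 300 nM in this assay. Compound 3 `CCOC(=O)c1cnc(CC2=CCCCC2)nc1NN1C(=O)C=C(C)C1=O` gives 2000 nM in this assay, which places it second highest of the three numbers: nearest to it stands compound 2, and the change is a 6.7-fold higher number from compound 2 to compound 3 (0.82 log units; beyond the scatter); furthest stands compound 1, and the change is an 8.0-fold lower number from compound 1 to compound 3 (0.90 log units; beyond the scatter).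

Compound 4 `CCOC(=O)c1cnc(-c2cc(Cl)cc(Cl)c2)nc1NN1C(=O)C=C(C)C1=O` has not yet been measured. It differs from compound 3 in one place: 3,5-dichlorophenyl in place of (cyclohex-1-en-1-yl)methyl on an aromatic carbon. For the measured compounds named here, two measured steps bear on this. Replacing methyl by 4-chlorophenyl produced a 53-fold lower number from compound 1 to compound 2 (1.73 log units; beyond the scatter), a large move, and swapping 4-chlorophenyl for (cyclohex-1-en-1-yl)methyl produced a 6.7-fold higher number from compound 2 to compound 3 (0.82 log units; beyond the scatter). Nothing is known about a second chlorine on the phenyl ring, so the effect of that part of the change is uncertain.

Returning to an aryl group is therefore expected to lower the number for compound 4 in this assay by about a 5.0-fold lower number from compound 3 to compound 4 (0.70 log units; beyond the scatter). Compound 4 is estimated at 400 nM, between 100 nM and 2000 nM.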

Compound 4, half-maximal inhibitory concentration: 300 nM
For compound 4 the middle estimate is 1.3-fold (0.12 log units) above the measured one, within the range that was stated.
By their numbers in this assay, from the lowest: compounds 2 and 4 (each within the scatter of the next); then compound 3; then compound 1.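

In this assay, for the compounds shown here, the step from one chlorine to two on the phenyl ring at the aromatic carbon between two ring nitrogen atoms shows no change at the digits printed from compound 2 to compound 4 (within the scatter) and so leaves the read-out where it stood, something the earlier compounds could not show, as they held only one chlorinated aryl group. The 3,5-dichlorophenyl group also reproduces the separation first seen with 4-chlorophenyl, with a 53-fold lower number from compound 1 to compound 4 (1.73 log units; beyond the scatter) against methyl and a 6.7-fold lower number from compound 3 to compound 4 (0.82 log units; beyond the scatter) against (cyclohex-1-en-1-yl)methyl, so in this small set both chlorinated phenyl groups stand apart from the two groups without an aromatic ring, and the second chlorine and altered substitution pattern add nothing beyond the scatter. No measured property of these groups is available to explain the differences at this position.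

From the compounds shown here alone, how an unsubstituted phenyl group, or a phenyl group carrying a methoxy or an amine, would read at this position stays open, so the contribution of the chlorine atoms cannot be separated from that of the aromatic ring itself. Also open, going by these compounds, is whether these aryl groups would keep their standing with a carboxylic acid in place of the ethoxycarbonyl group.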